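The source may hold more compounds than are shown below. What is called first, only, known or untested is meant among the compounds shown, and "the series" means these compounds.

Working notes on the series. Compound 1 `CCC1(Cc2ccccc2)OS(=O)(=O)C=C1OCc1ccc(Cl)cc1`, compound 2 `CCC1(Cc2ccccc2)OS(=O)(=O)C=C1OCc1ccc([N+](=O)[O-])cc1` and compound 3 `CCC1(Cc2ccccc2)OS(=O)(=O)C=C1OCCCc1ccccc1` share one core and differ only in the group on the saturated chain carbon bound to an oxygen on an unsaturated carbon. In an ADME assay on HEL cells (Homo sapiens) for cytotoxicity, with a stated time of 3 days (on this read-out higher numbers stand for lower toxicity in this test and lower numbers for higher toxicity in this test), compound 1 gives > 200000 nM, which is a limit of the assay and not a number. Compound 2 gives < 200000 nM in this assay, again a limit and not a number. Compound 3 gives 133000 nM in this assay. The measured steps are a number no higher from compound 1 to compound 2 (the limit leaves the size open), an at least 1.5-fold lower number from compound 1 to compound 3 (0.17 log units; that floor lies within the scatter) and a step that the limit leaves unreadable from compound 2 to compound 3; with the limit of < 200000 nM in this assay, at which 1 of the 3 values shown sits, and (the limit of > 200000 nM in this assay, at which 1 of the 3 values shown sits), none of them yields a readable size, so compound 2 stands only at its limit, somewhere at or under the values of the other two.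

Compound 4 `CCC1(Cc2ccccc2)OS(=O)(=O)C=C1OCc1ccc(C(F)(F)F)cc1` differs from compound 2 by trifluoromethyl in place of nitro on an aromatic carbon. Going by the values given here, no measured step covers a trifluoromethyl, and the steps touching compound 2 are unreadable, so no direction beyond the scatter can be expected; the working expectation is a step that the limit leaves unreadable from compound 2 to compound 4. Compound 4 is estimated at 180000 nM, within 70000 nM to 400000 nM.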

Compound 4, half-maximal cytotoxic concentration: 99000 nM
Compound 4: the middle estimate sits 1.8-fold (0.26 log units) above what was measured; the measured number falls inside the stated range.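

In this assay, compound 4 gives the first actual number, rather than a limit, for a benzyl-type group carrying a substituent on an aromatic carbon para to a large group. Trifluoromethyl in place of chloro gives an at least 2.0-fold lower number from compound 1 to compound 4 (0.30 log units; that floor lies within the scatter), so this change has a lower bound on its size but no exact size, and that bound does not clear the scatter. Compound 2 carries a limit and not a number, so its steps to the other compounds cannot be read: the limit of < 200000 nM in this assay, at which 1 of the 4 values shown sits.

As far as these compounds go, how an amine or a carboxylic acid on the same aromatic carbon would read in this assay remains open. So does the effect of a longer chain in place of phenethyl, and whether any group at this place gives a step clearly beyond the scatter.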